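Removing a Methoxy Group: What the Numbers Suggest

The compounds below may be only part of what the source reports. "The series", "measured", "known", "first", "only" and "open" are said of these compounds alone.

Measured compounds:
Compound 1, `CCc1ccc2nc(C(=O)Nc3c(F)cc(-c4cccc(F)c4)cc3F)c(C)c(O)c2c1`: in a functional assay on A-375 cells (Homo sapiens) for antiproliferative activity, read by MTT assay, with a stated time of 24 h, tested at 0.01 ug/mL (a higher number here means a stronger effect of the compound at the concentration tested, a lower number a weaker effect), compound 1 gives -0.35%.
Compound 2, `Cc1c(C(=O)Nc2c(F)cc(-c3cccc(F)c3)cc2F)nc2ccc(F)cc2c1O`: compound 2 gives -0.35%.
Compound 3, `COc1ccc2nc(C(=O)Nc3ccc(-c4ccccc4)cc3)c(C)c(O)c2c1`: compound 3 gives 0.13%.

Compound 3 shows the largest of the three numbers, yet its gaps to compound 1 and compound 2 both lie within the scatter, so the three stand together near zero. Compound 4, `Cc1c(C(=O)Nc2ccc(-c3ccccc3)cc2)nc2ccccc2c1O`, differs from compound 3 by hydrogen in place of methoxy on an aromatic carbon. For the measured compounds named here, the only measured step, no change at the digits printed from compound 1 to compound 2 (within the scatter), concerns a different change on the core, so no step bears directly on this one. With every value near zero and nothing pointing elsewhere, the step of a number 0.1 percentage points lower from compound 3 to compound 4 (within the scatter) is expected to stay within the scatter. Compound 4 is therefore estimated at 0%, in a range from -10% to 10%.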

Compound 4, a percentage reported as inhibition, at one concentration (the size of the read-out at that concentration, not a potency): -0.11%
The estimate for compound 4 lay 0.1 percentage points above the measured number; the measured number falls inside the stated range.
By their numbers in this assay, from the lowest: compounds 1, 2, 4 and 3 (each within the scatter of the next).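

In this assay, for the compounds shown here, the swap of methoxy for hydrogen on this aromatic carbon of the shared core gives a number 0.2 percentage points lower from compound 3 to compound 4 (within the scatter) and is the first measured step at this position. Methoxy can therefore give way to hydrogen here without a step beyond the scatter, although both compounds sit so close to zero that a loss could hardly show. Nothing measured on hand explains this result.

Still open, going by these compounds, is whether any group on this carbon can lift the read-out clear of zero. An amine or a carboxylic acid at this place would test that.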